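Thiosemicarbazide series: pyridyl swap on compound 3

The source may hold more compounds than are shown below. What is called first, only, known or untested is meant among the compounds shown, and "the series" means these compounds.

Measured compounds in a functional assay on A-431 cells (Homo sapiens) for cytotoxicity, read by MTT assay, with a stated time of 72 h, tested at 30 uM; on this read-out higher numbers stand for more inhibition of growth at the one concentration tested and lower numbers for less inhibition of growth:
- compound 1 `N/C(=N\NC(=S)N1CCSCC1)c1ccccn1`: 81.3%
- compound 2 `N/C(=N\NC(=S)N1CCOCC1)c1ccccn1`: 78.8%
- compound 3 `N/C(=N\NC(=S)N1CCN(c2ccccn2)CC1)c1ccc(F)cn1`: 62.3%

Compound 3 stands lowest of the three numbers in this assay. Its nearest neighbour is compound 2, whose value lies beyond the scatter above it, and compound 1 lies further above still. Within the data shown here, the single step that has been measured, a number 2.5 percentage points lower from compound 1 to compound 2 (within the scatter), concerns the thiocarbonyl side of the shared core and stays within the scatter; it says nothing about the aryl group on the other end.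

Compound 4 `Cc1ccnc(/C(N)=N/NC(=S)N2CCN(c3ccccn3)CC2)c1` differs from compound 3 only there: 4-methylpyridin-2-yl in place of 5-fluoropyridin-2-yl on a carbon with a double bond to nitrogen. Among the measured compounds shown here, no measured pair isolates a change of this kind. Compounds 1 and 2 carry an unsubstituted pyridin-2-yl at the same place, but they also differ from compound 3 on the thiocarbonyl carbon, so their gap to compound 3 cannot be assigned to the aryl group alone. For the measured compounds named here, with no step that bears on the change, no step beyond the scatter is expected in this assay, in either direction, and the estimate for compound 4 is kept close to compound 3 with a wide range.

For compound 4 the expected step is a number 1.7 percentage points higher from compound 3 to compound 4 (within the scatter), and the estimated value is 64% (range 45% to 80%).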

Compound 4, percent growth inhibition at one concentration: 65.7%
Beside the measured number, compound 4's estimate is 1.7 percentage points below it, and the stated range covers the measured number.
By their numbers in this assay, from the lowest: compounds 3 and 4 (each within the scatter of the next); then compounds 2 and 1 (each within the scatter of the next).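

In this assay, among these compounds, the first measured change at the aryl group on the carbon with a double bond to nitrogen gives a number 3.4 percentage points higher from compound 3 to compound 4 (within the scatter), so 4-methylpyridin-2-yl and 5-fluoropyridin-2-yl are not told apart at this place. The earlier compounds shown here could not show this, as they also differ from compound 3 on the thiocarbonyl carbon, whereas this pair keeps that side fixed and shows that exchanging these two substituted pyridyl groups leaves the percent growth inhibition within the usual scatter. No measurement bears on why the two groups read alike.

Still open, as far as these compounds go, is how the unsubstituted pyridin-2-yl of compound 1 would read with the thiocarbonyl side of compound 3, which would separate the contributions of the two places, and how groups of another kind at this place, such as a phenyl ring or a pyridin-2-yl carrying an amine or a carboxylic acid, would read. The single concentration tested also leaves open whether compound 3 and compound 4 would separate over a full concentration range.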